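Replacing the group on the ring nitrogen: compound 3 to compound 4

The compounds below may be only part of what the source reports. "The series", "measured", "known", "first", "only" and "open" are said of these compounds alone.

Compound 3 `CCc1cccc(Nc2cc(NC(=O)Nc3cc(OC)cc(OC)c3)ncn2)c1` stands lowest of the three measured numbers in a functional assay on NCI-H1581 cells (Homo sapiens) for inhibition, read by MTT assay, with a stated time of 48 h, tested at 10 uM (on this read-out lower numbers stand for less inhibition and higher numbers for more inhibition at the one concentration tested (going by the name of the read-out)), giving 27.7%. Compound 2 `CCc1ccc(Nc2cc(NC(=O)Nc3cc(OC)cc(OC)c3)ncn2)cc1` gives 32.7% in this assay, and compound 1 `COc1cc(NC(=O)Nc2cc(Nc3ccc(C(C)(C)C)cc3)ncn2)cc(OC)c1` gives 38.7%. The step of a number 11 percentage points lower from compound 1 to compound 3 (beyond the scatter) lies beyond the scatter but is modest; the step of a number 5 percentage points lower from compound 2 to compound 3 (within the scatter) lies within the scatter, as does a number 6 percentage points lower from compound 1 to compound 2 (within the scatter).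

Compound 4 `COc1cc(NC(=O)Nc2cc(Nc3cc(I)ccc3OC)ncn2)cc(OC)c1` differs from compound 3 by 5-iodo-2-methoxyphenyl in place of 3-ethylphenyl on a nitrogen on an aromatic ring. The measured steps that bear on this change are those that also exchange the group on the nitrogen on an aromatic ring, namely a number 11 percentage points lower from compound 1 to compound 3 (beyond the scatter) and a number 5 percentage points lower from compound 2 to compound 3 (within the scatter); both are small. Among the measured compounds shown here, none of the measured compounds carries an iodine or a methoxy on that group, so the entering 5-iodo-2-methoxyphenyl has no direct precedent, and the expectation rests only on the small size of the earlier exchanges. Compound 4 is therefore expected to sit close to compound 3 in this assay, with a step in either direction that is unlikely to exceed the scatter. For compound 4 the expected step is a number 2.3 percentage points higher from compound 3 to compound 4 (within the scatter). The estimate for compound 4 in this assay is 30%, with a range from 15% to 48%.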

Compound 4, a percentage reported as inhibition, at one concentration (the size of the read-out at that concentration, not a potency): 59%
Compound 4: the middle estimate sits 29 percentage points below what was measured, and the stated range ends below it.
By their numbers in this assay, from the lowest: compounds 3, 2 and 1 (each within the scatter of the next, the first and the last beyond it); then compound 4.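

The group on the nitrogen on an aromatic ring carries far more of the read-out in this assay than the alkyl-substituted phenyl groups suggested: the step is a number 31.3 percentage points higher from compound 3 to compound 4 (beyond the scatter) and stands well apart from the earlier exchanges at this place. The gain holds against each earlier group, with a number 26.3 percentage points higher from compound 2 to compound 4 (beyond the scatter) and a number 20.3 percentage points higher from compound 1 to compound 4 (beyond the scatter), so compound 4 stands beyond the scatter above all three, and 5-iodo-2-methoxyphenyl is the only group shown here that brings an oxygen, an iodine and a hydrogen-bond acceptor to this place. No measurement at hand explains the gain.

The iodine and the methoxy enter together, so their shares in the step remain unseparated, and a phenyl carrying only one of them, a chlorine or bromine in place of the iodine, or an ethoxy in place of the methoxy would be needed to divide it. Going by these compounds, the read-out also stands at one concentration, so whether the stronger effect at this place holds at other concentrations, and whether it persists with a group other than the 3,5-dimethoxyphenyl on the far side of the urea, stays open.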